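The source may report more compounds than this note shows. Statements on the series, on what has been measured and on what is new or still open speak of the compounds shown alone.

Measured compounds: compound 1 `COc1ccc(CO/N=C/c2c(C)nn(C)c2Oc2ccc(Cl)cc2)cc1`, 28.1%; compound 2 `Cc1ccc(CO/N=C/c2c(C)nn(C)c2Oc2ccc(Cl)cc2)cc1`, 30.4%; compound 3 `Cc1nn(C)c(Oc2ccccc2)c1/C=N/OCc1ccc(C(F)(F)F)cc1`, 11%; all in a functional assay on MKN-45 cells (Homo sapiens) for antiproliferative activity, tested at 1 uM; on this read-out lower numbers stand for less inhibition and higher numbers for more inhibition at the one concentration tested (going by the name of the read-out).

Compound 3 stands lowest of the three. Among the measured compounds shown here, compound 1 and compound 2 both carry a 4-chlorophenoxy group and lie higher by more than the scatter, but each also differs from compound 3 elsewhere, so their values show only that the chloro-bearing pair sits higher. Compound 4 `Cc1nn(C)c(Oc2ccc(Cl)cc2)c1/C=N/OCc1ccc(C(F)(F)F)cc1` differs from compound 3 by chloro in place of hydrogen on an aromatic carbon. For the measured compounds named here, the one measured step, a number 2.3 percentage points higher from compound 1 to compound 2 (within the scatter), concerns another position and does not bear on this change. Without a direct precedent, a modest rise toward the chloro-bearing pair is expected, a number 9 percentage points higher from compound 3 to compound 4 (within the scatter). Compound 4 is estimated at 20%, range 6% to 38%.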

Compound 4, a percentage reported as inhibition, at one concentration (the size of the read-out at that concentration, not a potency): 27.6%
Compound 4: the middle estimate sits 7.6 percentage points below what was measured; the measured number falls inside the stated range.
By their numbers in this assay, from the lowest: compound 3; then compounds 4, 1 and 2 (each within the scatter of the next).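

In this assay, among the compounds shown here, chloro in place of hydrogen gives the first reading of a single change at this position (a number 16.6 percentage points higher from compound 3 to compound 4 (beyond the scatter)). With the 4-chlorophenoxy group held constant, trifluoromethyl does not separate from methyl (a number 2.8 percentage points lower from compound 2 to compound 4 (within the scatter)) or from methoxy (a number 0.5 percentage points lower from compound 1 to compound 4 (within the scatter)). No measured evidence explains the chloro step. On these data alone, whether bromo or an amine on the same aromatic carbon would read like chloro stays open. Also open, as far as these compounds go, is whether the chloro step holds with methyl or methoxy in place of trifluoromethyl.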